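Phenyl carbamate in place of a fluorinated alkyl carbamate

A few compounds are considered here, and "the series" means these few. Any claim that something is new, unique, unknown or untested is made for them only; others in the source may bear on it.

Measured so far:
Compound 1 `CC(C)OC(=O)N1CCC(O[C@H]2CC[C@H](Oc3ccc(S(C)(=O)=O)nc3)CC2)CC1` gives 201 nM in a functional assay on isolated protein for agonist activity at Glucose-dependent insulinotropic receptor (Rattus norvegicus), read by HTRF and cAMP accumulation; on this read-out lower numbers stand for an effect already at smaller amounts and higher numbers for an effect only at larger amounts of compound.
Compound 2 `CC(C)(C)OC(=O)N1CCC(O[C@H]2CC[C@H](Oc3cnc(S(C)(=O)=O)cn3)CC2)CC1` gives 64 nM in this assay.
Compound 3 `C[C@H](CF)OC(=O)N1CCC(O[C@H]2CC[C@H](Oc3cnc(S(C)(=O)=O)cn3)CC2)CC1` gives 317 nM in this assay.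

Compound 3 has the highest number of the three. Its gap to compound 1 lies within the usual scatter, so the two cannot be ranked, while compound 2 sits clearly lower.

The new compound 4 `CS(=O)(=O)c1cnc(O[C@H]2CC[C@H](OC3CCN(C(=O)Oc4ccccc4)CC3)CC2)cn1` differs from compound 3 in one place: phenyl in place of 1-(fluoromethyl)ethyl on an oxygen next to a carbonyl group. The carbamate oxygen keeps its position; only the group on it changes.

Among the measured compounds shown here, only one measured step touches this oxygen: a 5.0-fold higher number from compound 2 to compound 3 (0.69 log units; beyond the scatter). That step shows that swapping the group here can move the number by a modest amount, but neither direction of a move to phenyl has a precedent among the measured compounds, and phenyl is a ring where the earlier groups were chains. Since compound 2 with tert-butyl gave 64 nM and compound 3 gave 317 nM, a value somewhere in that span seems most plausible, with a wide margin either way.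

Compound 4 is therefore expected to give about 180 nM in this assay, within a range of 50 nM to 700 nM. Relative to compound 3 this expectation means a 1.8-fold lower number from compound 3 to compound 4 (0.25 log units; within the scatter).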

Compound 4, half-maximal effective concentration: 71.8 nM
For compound 4 the middle estimate is 2.5-fold (0.40 log units) above the measured one; the measured number falls inside the stated range.
By their numbers in this assay, from the lowest: compounds 2 and 4 (each within the scatter of the next); then compounds 1 and 3 (each within the scatter of the next).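

On an oxygen next to a carbonyl group, swapping 1-(fluoromethyl)ethyl for phenyl gives a 4.4-fold lower number from compound 3 to compound 4 (0.64 log units; beyond the scatter) in this assay, so this position can respond in the favourable direction as well as the unfavourable one. Among the compounds shown here, until now, the only measured change here had been the loss on leaving tert-butyl, which could have suggested that tert-butyl was the group to keep. Phenyl in place of tert-butyl gives a 1.1-fold higher number from compound 2 to compound 4 (0.05 log units; within the scatter) in this assay, which means that a six-membered aromatic ring of carbon only and a group without a ring cannot be told apart on this read-out, and a ring on this oxygen is therefore compatible with a number as low as the best one shown.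

Still open, on these data alone, is whether a benzyl or cyclohexyl group on this oxygen, or a phenyl ring carrying a methoxy group or a chlorine atom, would hold, lower or raise the number. Nothing available here explains why these groups give the numbers they do.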